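From an Aromatic Amide Tail to a Pyrrolidine Chain

The compounds below may be only part of what the source reports. "The series", "measured", "known", "first", "only" and "open" are said of these compounds alone.

Of the compounds shown here, two built on one shared core have been tested in an ADME assay on L02 cells (Homo sapiens) for cytotoxicity, read by MTT assay, with a stated time of 72 h; a higher number here means a weaker inhibitor, a lower number a stronger inhibitor. Compound 1 `O=C(CCC(=O)OCCCCCCSc1ccc([N+](=O)[O-])c2nonc12)Nc1ccccc1` gives 6490 nM. Compound 2 `Cc1ccc(NC(=O)CCC(=O)OCCCCCCSc2ccc([N+](=O)[O-])c3nonc23)cc1` gives 7320 nM, the highest of the two numbers, with compound 1 as its nearest neighbour at a gap of a 1.1-fold higher number from compound 1 to compound 2 (0.05 log units; within the scatter). Compound 3 `O=C(CCC(=O)OCCCCCCSc1ccc([N+](=O)[O-])c2nonc12)NCCN1CCCC1` has not yet been measured in this assay. It differs from compound 2 as follows: 2-(pyrrolidin-1-yl)ethyl in place of 4-methylphenyl on an amide-type nitrogen. Within the data shown here, the only measured step, a 1.1-fold higher number from compound 1 to compound 2 (0.05 log units; within the scatter), concerns a methyl group on an aromatic carbon and says little about exchanging the whole 4-methylphenyl group for a 2-(pyrrolidin-1-yl)ethyl group. On the two compounds shown, the amide tail has not moved the number, so no step beyond the scatter is expected here either, though the basis is thin. Compound 3 is therefore estimated at 7500 nM, within 3000 nM to 18000 nM, an expected step of a 1.0-fold higher number from compound 2 to compound 3 (0.01 log units; within the scatter).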

Compound 3, half-maximal inhibitory concentration: 6580 nM
Compound 3: the middle estimate sits 1.1-fold (0.06 log units) above what was measured; low and high end bracket the measured number.
By their numbers in this assay, from the lowest: compounds 1, 3 and 2 (each within the scatter of the next).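

In this assay the exchange of 4-methylphenyl for 2-(pyrrolidin-1-yl)ethyl on the amide-type nitrogen gives a 1.1-fold lower number from compound 2 to compound 3 (0.05 log units; within the scatter) and the exchange of phenyl for the same group gives a 1.0-fold higher number from compound 1 to compound 3 (0.01 log units; within the scatter). The earlier pair differed only by a methyl group on an aromatic carbon, whereas this change removes the six-membered aromatic ring entirely and puts a five-membered non-aromatic ring with a nitrogen in its place. Even so, the three compounds cannot be told apart in this read-out, and no measurement shown offers an explanation for that.

As far as these compounds go, whether a carboxylic acid or a longer chain on the amide-type nitrogen would also leave the number within the scatter remains open. So does the effect of any change elsewhere in the molecule, away from this amide.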